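Swapping methoxy for fluoro: compound 2 to compound 3

The source may report more compounds than this note shows. Statements on the series, on what has been measured and on what is new or still open speak of the compounds shown alone.

In a functional assay on HeLa cells (Homo sapiens) for antiproliferative activity, read by MTT assay, with a stated time of 72 h (a higher number here means a weaker inhibitor, a lower number a stronger inhibitor), compound 1 `CC(C)N1C(=O)COc2ccc(-c3cccc(NS(=O)(=O)c4ccc(F)cc4)c3)cc21` gives 22700 nM and compound 2 `COc1ccc(N2C(=O)COc3ccc(-c4cccc(NS(=O)(=O)c5ccc(F)cc5)c4)cc32)cc1` gives 13200 nM. These two values lie within the scatter of each other, so compound 2 cannot be ranked apart from compound 1.

Compound 3 `O=C1COc2ccc(-c3cccc(NS(=O)(=O)c4ccc(F)cc4)c3)cc2N1c1ccc(F)cc1` keeps the rest of compound 2 and alters one group: fluoro in place of methoxy on an aromatic carbon, para to a large group, which turns 4-methoxyphenyl into 4-fluorophenyl (fluoro in place of methoxy on an aromatic carbon).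

Among the measured compounds shown here, only one measured step bears on this change: a 1.7-fold lower number from compound 1 to compound 2 (0.24 log units; within the scatter). That step put the 4-methoxyphenyl group in place of isopropyl on an amide-type nitrogen in a ring. Even that exchange of a whole group stayed within the scatter. The new change edits only the outer end of the same group, so no step beyond the scatter is expected, in either direction. For the measured compounds named here, this rests on a single step, and no measured compound carries fluoro there.

The expected result is a 1.1-fold higher number from compound 2 to compound 3 (0.03 log units; within the scatter). Compound 3 is estimated at 14000 nM, with an expected range of 6000 nM to 32000 nM.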

Compound 3, half-maximal inhibitory concentration: > 40000 nM
Compound 3: no number, only a limit (the forecaster's own chance of this, stated with the estimate: 10%); at least 2.8-fold (0.45 log units) between middle value and limit.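

In this assay compound 3 gives > 40000 nM, which is a limit of the assay and not a number. Among the compounds shown here, this position is more sensitive than the earlier compounds suggested: fluoro in place of methoxy on an aromatic carbon, a change of a single group at the outer end of the ring, gives an at least 3.0-fold higher number from compound 2 to compound 3 (0.48 log units; beyond the scatter), whereas the earlier exchange of the whole group on the ring nitrogen, a 1.7-fold lower number from compound 1 to compound 2 (0.24 log units; within the scatter), did not move beyond the scatter. The comparison with the isopropyl compound is an at least 1.7-fold higher number from compound 1 to compound 3 (0.24 log units; that floor lies within the scatter), so that floor alone does not separate the two, and the true size of both new steps stays unknown, with this the only fact on record about the reading: the limit of > 40000 nM in this assay, at which 1 of the 3 values shown sits.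

The compounds shown leave open whether methoxy is special or whether fluoro is simply a poor fit here, since a plain phenyl ring, a chloro group, a hydroxyl, an amine or a longer ether such as ethoxy at the same place could side with either. With one methoxy compound and one limit, no trend across groups at this position can yet be drawn.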